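A Second Pyrrolidine Urea on the Shared Core

The compounds below may be only part of what the source reports. "The series", "measured", "known", "first", "only" and "open" are said of these compounds alone.

Measured compounds:
Compound 1, `Cc1cc(C(=O)N2CCCCc3ccccc32)ccc1CNC(=O)Nc1ccccc1`: 130 nM
Compound 2, `Cc1cc(C(=O)N2CCCCc3ccccc32)ccc1CNC(=O)NCC(=O)OC(C)(C)C`: 120 nM
Compound 3, `Cc1cc(C(=O)N2CCCCc3ccccc32)ccc1CNC(=O)N1CCC[C@H]1C(=S)N(C)C`: 3.2 nM

All three were tested in a functional assay on HEK293 cells for agonist activity at Vasopressin V2 receptor (Homo sapiens), read by a luciferase reporter and cAMP accumulation; a higher number here means that more compound is needed for the effect, a lower number that less compound is needed. Compound 3 gives the lowest number of the three; compound 2 lies a 38-fold lower number from compound 2 to compound 3 (1.57 log units; beyond the scatter) and compound 1 lies a 41-fold lower number from compound 1 to compound 3 (1.61 log units; beyond the scatter), both steps well beyond the scatter. Compounds 1 and 2 differ from each other only within the scatter, so they count as alike.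

Compound 4, `CO[C@@H]1C[C@@H](C(=O)N(C)C)N(C(=O)NCc2ccc(C(=O)N3CCCCc4ccccc43)cc2C)C1`, has not yet been measured in this assay. Its difference from compound 3 is a group of 12 heavy atoms (8 carbon, 2 nitrogen, 2 oxygen; one five-membered non-aromatic ring with 1 hetero atom) in place of a group of 10 heavy atoms (7 carbon, 2 nitrogen, 1 sulfur; one five-membered non-aromatic ring with 1 hetero atom), on a carbonyl carbon. Both compounds therefore carry a five-membered ring bearing a dimethyl-substituted group on the urea carbonyl; compound 4 adds a methoxy on that ring and replaces the sulfur with oxygen.

The two measured steps, from compound 1 to compound 3 and from compound 2 to compound 3, show that putting this kind of ring on the carbonyl gives a large drop in the number. Neither step speaks to the sulfur-for-oxygen swap or to the added methoxy, so no further direction can be read from the data. Compound 4 is expected to stay close to compound 3, a step of a 1.3-fold higher number from compound 3 to compound 4 (0.10 log units; within the scatter) within the scatter. The estimate for compound 4 is 4 nM, ranging from 1.3 nM to 14 nM.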

Compound 4, half-maximal effective concentration: 4.7 nM
The estimate for compound 4 lay 1.2-fold (0.07 log units) below the measured number, and the stated range covers the measured number.
By their numbers in this assay, from the lowest: compounds 3 and 4 (each within the scatter of the next); then compounds 2 and 1 (each within the scatter of the next).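

In this assay the step of a 1.5-fold higher number from compound 3 to compound 4 (0.17 log units; within the scatter) leaves the two compounds alike, so sulfur is not required for a low number at this place on the carbonyl carbon: 2-(dimethylcarbamoyl)-4-methoxypyrrolidin-1-yl carries no sulfur and has an extra methoxy, yet the number stays in the same range. Compound 4 also keeps the large gain over the earlier ureas, with a 26-fold lower number from compound 2 to compound 4 (1.41 log units; beyond the scatter) against the ((tert-butoxycarbonyl)methyl)amino group and a 28-fold lower number from compound 1 to compound 4 (1.44 log units; beyond the scatter) against anilino, so among these four compounds both pyrrolidine groups sit far from both open-chain and aromatic amino groups, and none goes against this. No measurement shown here explains why these pyrrolidine groups give the lower numbers.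

Since oxygen for sulfur and the added methoxy arrive in a single step, the result cannot say what each does alone, and they could even be offsetting each other. A pyrrolidine with the dimethylcarbamoyl group but no methoxy would separate the two, while the compounds shown leave open whether a carboxylic acid in place of the dimethylcarbamoyl group, or a hydroxy in place of the methoxy, would keep the number this low.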